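Lengthening a Side-Chain Amine in a Transporter Series

The source may hold more compounds than are shown below. What is called first, only, known or untested is meant among the compounds shown, and "the series" means these compounds.

Of the compounds shown here, three that share one core have been measured. Compound 1 `CCCCCCCCCCc1ccc(-c2noc(CN)n2)cc1` carries an aminomethyl group on that core, and in an assay on HeLa cells for inhibition of sphingosine-1-phosphate transporter SPNS2 (Mus musculus), read by LC-MS, tested at 2 uM (a lower number here means less inhibition, a higher number more inhibition at the concentration tested (going by the name of the read-out)), compound 1 gives 62%. Compound 2 `CCCCCCCCCCc1ccc(-c2noc([C@H]3CCCN3)n2)cc1`, with a pyrrolidin-2-yl group in the same place, gives 12%, and the step of a number 50 percentage points lower from compound 1 to compound 2 (beyond the scatter) is the largest seen here. Compound 3 `CCCCCCCCCCc1ccc(-c2noc([C@@H](N)CCCN)n2)cc1` gives 40%, the second highest of the three values: its nearest neighbour is compound 1, with the step of a number 22 percentage points lower from compound 1 to compound 3 (beyond the scatter), and its furthest is compound 2, with the step of a number 28 percentage points higher from compound 2 to compound 3 (beyond the scatter).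

The next compound, compound 4 `CCCCCCCCCCc1ccc(-c2noc([C@@H](N)CCCCN)n2)cc1`, differs from compound 3 by aminomethyl in place of amino on a saturated chain carbon, four bonds along the chain from an amine nitrogen and an aromatic carbon. Among the compounds with values here, no measured step changes a chain by a single carbon in this way; the two steps that reach compound 3 each exchange a whole group and still give only modest steps. A change of one carbon in the side chain is therefore expected to move this assay little, and most likely not beyond the scatter in either direction.

For compound 4 the expected value in this assay is 40%, within a range of 22% to 58%. This estimate means an expected step of no change at the digits printed from compound 3 to compound 4 (within the scatter).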

Compound 4, a percentage reported as inhibition, at one concentration (the size of the read-out at that concentration, not a potency): 43%
Estimate against measurement, compound 4: 3 percentage points below, and the stated range covers the measured number.
By their numbers in this assay, from the lowest: compound 2; then compounds 3 and 4 (each within the scatter of the next); then compound 1.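

Going from 3-aminopropyl to 4-aminobutyl on this saturated chain carbon gives a result that cannot be told apart from no change (a number 3 percentage points higher from compound 3 to compound 4 (within the scatter)) in this assay, so at this position the extra carbon makes no readable difference. Measured against the unbranched aminomethyl compound, the longer chain still carries a cost (a number 19 percentage points lower from compound 1 to compound 4 (beyond the scatter)), of the same modest class as the one printed for the shorter chain (a number 22 percentage points lower from compound 1 to compound 3 (beyond the scatter)), while the open 1,5-diaminopentyl group stands well clear of the pyrrolidin-2-yl group (a number 31 percentage points higher from compound 2 to compound 4 (beyond the scatter)). Nothing measured here explains why these two chain lengths read alike.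

Two chain lengths cannot define a trend, so a shorter 2-aminoethyl or a longer 5-aminopentyl chain on the same carbon would be needed to show whether the reading holds across a wider range of lengths. Going by these compounds, it also remains open whether the amine of the chain matters at all, which a carboxylic acid or a plain alkyl chain in its place could test.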